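The source may hold more compounds than are shown below. What is called first, only, known or untested is meant among the compounds shown, and "the series" means these compounds.

Working notes on the series, all read in an ADME assay on MRC5 cells (Homo sapiens) for cytotoxicity, read by neutral red uptake; a lower number here means that less compound is tolerated, a higher number that more compound is tolerated. Compound 1 `O=c1[nH]c(SCc2cc([N+](=O)[O-])cc([N+](=O)[O-])c2)nc2ccccc12` gives > 64000 nM, which is a limit of the assay and not a number. Compound 2 `Cc1ccc2nc(SCc3cc([N+](=O)[O-])cc([N+](=O)[O-])c3)[nH]c(=O)c2c1` gives > 64000 nM, again a limit only, so compound 2 has no number to stand on. The record so far is the limit of > 64000 nM in this assay, at which 2 of the 2 values shown sit.

Compound 3 `O=c1[nH]c(SCc2cc([N+](=O)[O-])cc([N+](=O)[O-])c2)nc2ccc(F)cc12` is the next entry, and it departs from compound 2 as follows: fluoro in place of methyl on an aromatic carbon. In words, this is fluoro in place of methyl on an aromatic carbon. Going by the values given here, the one measured step that bears on this change is a step that the two limits leave unreadable from compound 1 to compound 2, methyl in place of hydrogen on an aromatic carbon. It offers no size to carry over. No step beyond the scatter is therefore expected in this assay, and no direction can be argued. The expected change is a number no higher from compound 2 to compound 3 (the limit leaves the size open). This expectation rests on compound 2, whose > 64000 nM is a limit. Compound 3 is estimated at 64000 nM, with an expected range of 32000 nM to 128000 nM, and a further limit rather than a number is the likely report.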

Compound 3, half-maximal cytotoxic concentration: > 64000 nM
Compound 3: a limit, no number; the forecaster's own chance of this, stated with the estimate: 80%; the middle value sits exactly at the limit.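

Going by these compounds alone, compound 1, compound 2 and compound 3 all report limits and not numbers in this assay, so no step among them can be read. The compounds shown leave open how tolerated each one actually is, and whether methyl or fluoro in place of hydrogen on the shared core changes that at all: the limit of > 64000 nM in this assay, at which 3 of the 3 values shown sit.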